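A Larger Group Replaces the Sulfur Hydrogen of Compound 1

This account rests on a few compounds, and the source may have more. Where it says the series, first, only, none or still open, it means among the compounds named here.

Compound 1 `COc1ccc(-n2c(S)nnc2-c2cc(OC)c(OC)c(OC)c2)cc1` carries a hydrogen on a sulfur joined to its core. In a functional assay on HCT-116 cells (Homo sapiens) for inhibition, read by MTT assay, with a stated time of 48 h (a higher number here means a weaker inhibitor, a lower number a stronger inhibitor), compound 1 reaches only the limit of > 60000 nM, which is a limit and not a number. Compound 2 `COc1ccc(-n2c(SCc3ccccc3)nnc2-c2cc(OC)c(OC)c(OC)c2)cc1` carries benzyl on that sulfur and gives 42400 nM in this assay. Compound 3 `COc1ccc(-n2c(SCc3ccc(F)cc3)nnc2-c2cc(OC)c(OC)c(OC)c2)cc1` carries 4-fluorobenzyl there and gives 38700 nM. The steps of an at least 1.4-fold lower number from compound 1 to compound 2 (0.15 log units; that floor lies within the scatter) and an at least 1.5-fold lower number from compound 1 to compound 3 (0.19 log units; that floor lies within the scatter) point the same way, yet each only sets a floor, since they start from a limit (the limit of > 60000 nM in this assay, at which 1 of the 3 values shown sits). Between the two capped compounds, a 1.1-fold lower number from compound 2 to compound 3 (0.04 log units; within the scatter) shows no real change.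

Compound 4 `COc1ccc(-n2c(SCC(=O)c3ccc(OC)c(O)c3)nnc2-c2cc(OC)c(OC)c(OC)c2)cc1` makes the change (((3-hydroxy-4-methoxyphenyl)carbonyl)methyl in place of hydrogen on a sulfur). As with benzyl and 4-fluorobenzyl, a larger group takes the place of the sulfur hydrogen, and the steps to compound 2 and compound 3 are the ones that bear on it; both were small at their floor. The expected step is an at least 1.7-fold lower number from compound 1 to compound 4 (0.23 log units; that floor lies within the scatter), toward a lower number. Compound 4 is estimated at 35000 nM, with a range from 15000 nM to 80000 nM.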

Compound 4, half-maximal inhibitory concentration: > 60000 nM
Compound 4 ended at the assay's limit; the forecaster's own chance of this, stated with the estimate: 25%; middle value at least 1.7-fold (0.23 log units) away from the limit.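

Compound 4 shows that a larger group on this sulfur does not by itself lower the number: in this assay compound 4 gives > 60000 nM, which is a limit of the assay and not a number. Going by these compounds alone, replacing the benzyl groups with the carbonyl-bearing group points the opposite way from the earlier steps, with an at least 1.5-fold higher number from compound 3 to compound 4 (0.19 log units; that floor lies within the scatter) and an at least 1.4-fold higher number from compound 2 to compound 4 (0.15 log units; that floor lies within the scatter), so the direction is suggested but the true size stays unknown. The step between compound 1 and compound 4 cannot be read, as both stand at the same limit: the limit of > 60000 nM in this assay, at which 2 of the 4 values shown sit.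

As far as these compounds go, it remains open whether an ethyl chain, a carboxylic acid or an amine on this sulfur would bring the number clearly below the limit. From the compounds shown here alone, it is also open whether (phenylcarbonyl)methyl, without the hydroxy and methoxy, would stay at the limit too.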